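Adding a 2-hydroxyethyl group to compound 2

A few compounds are considered here, and "the series" means these few. Any claim that something is new, unique, unknown or untested is made for them only; others in the source may bear on it.

- Compound 1 `COc1cc(Sc2c[nH]c3ccc(I)cc23)cc(OC)c1OC` gives 68 nM
- Compound 2 `COc1cc(Sc2c[nH]c3ccc(O)cc23)cc(OC)c1OC` gives 190 nM

Both values come from a functional assay on MCF7 cells (Homo sapiens) for inhibition, with a stated time of 48 h (on this read-out lower numbers stand for stronger inhibition and higher numbers for weaker inhibition), where compound 2 holds the higher of the two numbers. Compound 3 `COc1cc(Sc2c[nH]c3ccc(OCCO)cc23)cc(OC)c1OC` differs from it by 2-hydroxyethyl in place of hydrogen on an oxygen on an aromatic ring. For the measured compounds named here, only one measured step bears on this change: hydroxy in place of iodo on an aromatic carbon gave a 2.8-fold higher number from compound 1 to compound 2 (0.45 log units; beyond the scatter), a modest step. It offers no direction for the new change. The expected 1.3-fold lower number from compound 2 to compound 3 (0.10 log units; within the scatter) is therefore small, probably no larger than that modest step and perhaps within the scatter. Compound 3 is estimated at 150 nM, with an expected range from 50 nM to 450 nM.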

Compound 3, half-maximal inhibitory concentration: 95 nM
Estimate against measurement, compound 3: 1.6-fold (0.20 log units) above; the range from low to high includes it.
By their numbers in this assay, from the lowest: compounds 1, 3 and 2 (each within the scatter of the next, the first and the last beyond it).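

In this assay, 2-hydroxyethyl in place of hydrogen on this oxygen gives a 2.0-fold lower number from compound 2 to compound 3 (0.30 log units; within the scatter) and so stays within the scatter. 2-Hydroxyethoxy in place of iodo gives a 1.4-fold higher number from compound 1 to compound 3 (0.15 log units; within the scatter) and also stays within it, so compound 3 cannot be told apart from either compound 1 or compound 2, although those two differ beyond the scatter. Nothing shown gives a reason for this result. As far as these compounds go, how a longer chain, or a chain carrying an amine or a carboxylic acid, would read on this oxygen remains open.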